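A pyridin-3-yl swap on compound 2

The source may report more compounds than this note shows. Statements on the series, on what has been measured and on what is new or still open speak of the compounds shown alone.

In a functional assay on MDA-MB-231 cells (Homo sapiens) for inhibition, read by MTT assay, with a stated time of 48 h (on this read-out higher numbers stand for weaker inhibition of growth and lower numbers for stronger inhibition of growth), compound 1 (`O=S(=O)(Nc1nccs1)c1ccc(NC(=S)Nc2ccc3ncnc(Nc4cccc(Br)c4)c3c2)cc1`) gives > 30000 nM, which is a limit of the assay. Within the data shown here, compound 2 (`FC(F)(F)c1ccc(NC(=S)Nc2ccc3ncnc(Nc4cccc(Br)c4)c3c2)cc1`) gives 12200 nM, the only actual number so far. Compound 3 (`S=C(Nc1cccnc1)Nc1ccc2ncnc(Nc3cccc(Br)c3)c2c1`) has pyridin-3-yl in place of 4-(trifluoromethyl)phenyl on an amide-type nitrogen. Among the measured compounds shown here, the only measured step, an at least 2.4-fold lower number from compound 1 to compound 2 (0.39 log units; beyond the scatter), also alters that aryl group, but it starts from the limit of > 30000 nM in this assay, at which 1 of the 2 values shown sits, and so gives only a loose guide. On that basis, the expected change is small and within the scatter, a 1.3-fold higher number from compound 2 to compound 3 (0.12 log units; within the scatter). The estimated value for compound 3 is 16000 nM, with an expected range of 6500 nM to 30000 nM.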

Compound 3, concentration for 50% growth inhibition: > 30000 nM
Compound 3: only a limit was reported (the forecaster's own chance of this, stated with the estimate: 25%); middle value at least 1.8-fold (0.27 log units) from the limit.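

In this assay, the step of an at least 2.4-fold higher number from compound 2 to compound 3 (0.39 log units; beyond the scatter) shows that the number at this amide-type nitrogen also rises when 4-(trifluoromethyl)phenyl gives way to a ring without that group, here pyridin-3-yl. The value of compound 3, > 30000 nM, is a limit and not a number, so the step gives only a direction and a minimum size. How far compound 3 lies past compound 2 cannot be told: the limit of > 30000 nM in this assay, at which 2 of the 3 values shown sit.

Going by these compounds, it remains open whether a phenyl ring carrying an amine or a carboxylic acid at this nitrogen would keep a measurable number. The same holds for a pyridine ring carrying trifluoromethyl.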